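The compounds below may be only part of what the source reports. "The series", "measured", "known", "first", "only" and "open" are said of these compounds alone.

Compound 1 `COc1ccc(C2OC(c3cc(OC)c(OC)c(OC)c3)=NN2C(C)=O)c(OC)c1` stands highest of the two numbers in hand: in a functional assay on PC-3 cells (Homo sapiens) for antiproliferative activity, read by MTT assay, tested at 1 uM (a higher number here means a stronger effect of the compound at the concentration tested, a lower number a weaker effect), compound 1 gives 69.5%. Among the measured compounds shown here, compound 2 `COc1cc(/C=N/NC(=O)c2cc(OC)c(OC)c(OC)c2)cc(OC)c1OC` is the only other measured compound, and in this assay compound 2 gives 8.5%, a value lying well beyond the scatter below that of compound 1. Compound 3 `COc1cc(C2=NN(C(C)=O)C(c3cccc(C(F)(F)F)c3)O2)cc(OC)c1OC` differs from compound 1 in one place: 3-(trifluoromethyl)phenyl in place of 2,4-dimethoxyphenyl on a saturated ring carbon. For the measured compounds named here, no step between measured compounds with this change is available. Compound 3 is expected to fall short of compound 1 by a number 24.5 percentage points lower from compound 1 to compound 3 (beyond the scatter), a step beyond the scatter. Compound 3 is estimated at 45% in this assay, within 15% to 75%.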

Compound 3, a percentage reported as inhibition, at one concentration (the size of the read-out at that concentration, not a potency): 30.1%
For compound 3 the middle estimate is 14.9 percentage points above the measured one, and the stated range covers the measured number.
By their numbers in this assay, from the lowest: compound 2; then compound 3; then compound 1.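

In this assay, among the compounds shown here, the first step at this saturated ring carbon shows that the substituent there matters: 3-(trifluoromethyl)phenyl in place of 2,4-dimethoxyphenyl gives a large loss (a number 39.4 percentage points lower from compound 1 to compound 3 (beyond the scatter)). Nothing at hand explains this drop. The change removes the two methoxy groups and brings in trifluoromethyl in a single step, and the compounds shown do not separate these two parts. From the compounds shown here alone, how an unsubstituted phenyl or a dimethylaminophenyl at this carbon would compare with compound 1 remains open.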